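This account rests on a few compounds, and the source may have more. Where it says the series, first, only, none or still open, it means among the compounds named here.

Measured compounds:
- compound 1 `CCC(=O)c1ccc2oc(CS(=O)(=O)c3nnc(CNc4ccccc4)n3CC)nc2c1` gives 1670 nM in an assay on isolated protein for inhibition of long-chain fatty acid transport protein 1 (Homo sapiens); on this read-out higher numbers stand for weaker inhibition and lower numbers for stronger inhibition
- compound 2 `CCn1c(CNc2ccccc2)nnc1SCC(=O)Nc1ccc(Cl)cc1` gives > 1000 nM in this assay, a limit and not a number
- compound 3 `CCn1c(CNc2ccccc2)nnc1SCc1nc2cc(C(=O)C(C)C)ccc2o1` gives 600 nM in this assay

Compound 2 stands at the limit of this assay, as the line the limit of > 1000 nM in this assay, at which 1 of the 3 values shown sits, records, and so its position among the three values is not fixed. Compound 4 `CCn1c(CNc2ccccc2)nnc1SCC(=O)Nc1ccc(C(=O)NC)cc1` differs from compound 2 by methylcarbamoyl in place of chloro on an aromatic carbon. Among the measured compounds shown here, no measured pair shows this change, so no step is known for it. Compound 4 is expected at 2000 nM, within 600 nM to 8000 nM. The expected step that the limit leaves unreadable from compound 2 to compound 4 is none beyond the scatter, and a second limit is considered likely.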

Compound 4, half-maximal inhibitory concentration: > 1000 nM
Compound 4 ended at the assay's limit; the forecaster's own chance of this, stated with the estimate: 60%; the middle value does not contradict the limit.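

In this assay compound 2 and compound 4 both stand at a limit, and no step can be read between them: the limit of > 1000 nM in this assay, at which 2 of the 4 values shown sit. How far methylcarbamoyl in place of chloro on an aromatic carbon shifts inhibition in this assay stays open among the compounds shown.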